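This account rests on a few compounds, and the source may have more. Where it says the series, first, only, none or still open, it means among the compounds named here.

The compounds here share one core, as seen in compound 1 `OC[C@H]1O[C@@H](n2cnc3c(OCc4ccccc4)ncnc32)[C@H](O)[C@@H]1O`, and are compared in an assay on isolated protein for binding affinity to Equilibrative nucleoside transporter 1 (Homo sapiens); on this read-out lower numbers stand for stronger inhibition and higher numbers for weaker inhibition. In this assay compound 1 gives 2090 nM, compound 2 `Cc1ccc(CSc2ncnc3c2ncn3[C@@H]2O[C@H](CO)[C@@H](O)[C@H]2O)cc1` gives 457 nM, and compound 3 `Cc1cc(C)c(SCc2ncnc3c2ncn3[C@@H]2O[C@H](CO)[C@@H](O)[C@H]2O)c(C)c1` gives 33100 nM, the highest of the three numbers, lying well beyond the scatter from both others. Compound 4 `OC[C@H]1O[C@@H](n2cnc3c(CSc4ccccc4Cl)ncnc32)[C@H](O)[C@@H]1O` has not yet been measured; it differs from compound 3 by 2-chlorophenyl in place of 2,4,6-trimethylphenyl on a sulfur. Within the data shown here, no measured pair alters this exact place. Among the measured compounds shown here, the only single-point step, a 4.6-fold lower number from compound 1 to compound 2 (0.66 log units; beyond the scatter), touched a different position and is modest, so it offers no direct guide. For the measured compounds named here, what the numbers do show is that compound 3, the only one carrying the trimethylated ring, stands far above compounds 1 and 2, which carry an unsubstituted or singly substituted ring. On that basis the number for compound 4 is expected to fall, with an estimated step of a 22-fold lower number from compound 3 to compound 4 (1.34 log units; beyond the scatter), though the size is uncertain. Compound 4 is estimated at 1500 nM, within a range from 250 nM to 9000 nM.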

Compound 4, half-maximal inhibitory concentration: 1780 nM
Estimate against measurement, compound 4: 1.2-fold (0.07 log units) below; measured number inside the range.
By their numbers in this assay, from the lowest: compound 2; then compounds 4 and 1 (each within the scatter of the next); then compound 3.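

With the link from the core to the sulfur kept the same, replacing 2,4,6-trimethylphenyl with 2-chlorophenyl on that sulfur gives a 19-fold lower number from compound 3 to compound 4 (1.27 log units; beyond the scatter) in this assay, so the high number of compound 3 does not come with this link alone. Changing the whole side group matters less in the other comparisons: a 3.9-fold higher number from compound 2 to compound 4 (0.59 log units; beyond the scatter) is beyond the scatter, whereas a 1.2-fold lower number from compound 1 to compound 4 (0.07 log units; within the scatter) is within it, so compound 1 and compound 4 cannot be told apart. Nothing measured here explains the size of the large step.

Because the methyl groups leave and a chlorine enters in one step, the compounds shown cannot separate the two changes. As far as these compounds go, it also remains open where a plain phenyl ring, or a phenyl ring carrying a methoxy group or an amine, would fall on this sulfur.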